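A Methoxy Added to Compound 2

The source may report more compounds than this note shows. Statements on the series, on what has been measured and on what is new or still open speak of the compounds shown alone.

- Compound 1 `CC(C)(C)/N=c1\c(O)c(O)\c1=N/c1cnc2ccccc2c1`: > 30000 nM (a limit of the assay)
- Compound 2 `CC(/N=c1\c(O)c(O)\c1=N/c1cccc2cccnc12)C(C)(C)C`: 8100 nM

Compound 1 reaches only a limit in a functional assay for inhibition, with Rattus norvegicus as the target (on this read-out lower numbers stand for stronger inhibition and higher numbers for weaker inhibition), not a number. Going by the values given here, compound 2, at 8100 nM, holds the only actual number so far. Compound 3 `COc1cc(/N=c2\c(O)c(O)\c2=N/C(C)C(C)(C)C)c2ncccc2c1` differs from compound 2 in one place: methoxy in place of hydrogen on an aromatic carbon. This puts methoxy in place of hydrogen on an aromatic carbon. Among the compounds with values here, no measured pair shows what such a change does, so no shift beyond the usual scatter is expected in this assay, and no direction is favoured. The expected change is a 1.2-fold lower number from compound 2 to compound 3 (0.06 log units; within the scatter). For compound 3 the estimated value is 7000 nM, with an expected range from 2000 nM to 25000 nM.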

Compound 3, half-maximal inhibitory concentration: > 30000 nM
Compound 3: a limit, no number; the forecaster's own chance of this, stated with the estimate: 15%; middle value at least 4.2-fold (0.63 log units) from the limit.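

Going by these compounds alone, this is the first measured effect of a change at this position: methoxy in place of hydrogen on an aromatic carbon, meta to a large group, gives an at least 3.7-fold higher number from compound 2 to compound 3 (0.56 log units; beyond the scatter) in this assay, which means weaker inhibition. Compound 3 reaches only a limit of the assay, so the step has a known minimum but no known full size: the limit of > 30000 nM in this assay, at which 2 of the 3 values shown sit.

On these data alone, whether fluorine, a hydroxyl or an amine at this position would also weaken inhibition stays open. One change also cannot show whether methoxy would behave the same way on another carbon of this ring.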